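The source may hold more compounds than are shown below. What is called first, only, known or untested is meant among the compounds shown, and "the series" means these compounds.

Measured so far in a functional assay on HCT-116 cells (Homo sapiens) for antiproliferative activity, read by MTT assay, with a stated time of 72 h (a higher number here means a weaker inhibitor, a lower number a stronger inhibitor), for this series:

Compound 1 (`COc1ccc(-c2c(CN3CCCCC3)nc3scc(C(=O)O)n23)cc1`): 84600 nM
Compound 2 (`CC(=O)NNC(=O)c1csc2ncc(-c3ccc(C)cc3)n12`): 71800 nM
Compound 3 (`CCC(=O)NNC(=O)c1csc2ncc(-c3ccc(C)cc3)n12`): 9230 nM

Compound 3 has the lowest of these three numbers, and both other compounds lie beyond the scatter from it. Compound 4 (`CCCC(=O)NNC(=O)c1csc2ncc(-c3ccc(C)cc3)n12`) has not yet been measured. Its structure differs from that of compound 3 by methyl in place of hydrogen on a saturated chain carbon, two bonds along the chain from a carbonyl carbon in the side chain, which reads as ethyl to propyl when cut one bond further out. Among the compounds with values here, one measured step bears on this change: a 7.8-fold lower number from compound 2 to compound 3 (0.89 log units; beyond the scatter) came from methyl in place of hydrogen on a saturated chain carbon bound to a carbonyl carbon. This single step shows no trend, and the new methyl sits on a different chain carbon. In this assay a further lowering in the same direction is therefore expected, but a smaller one. The expected change is a 1.8-fold lower number from compound 3 to compound 4 (0.27 log units; within the scatter) by this estimate. The estimated value for compound 4 is 5000 nM with 1500 nM to 20000 nM as its expected range.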

Compound 4, half-maximal inhibitory concentration: 34500 nM
Beside the measured number, compound 4's estimate is 6.9-fold (0.84 log units) below it; the whole stated range lies below it.
By their numbers in this assay, from the lowest: compound 3; then compound 4; then compounds 2 and 1 (each within the scatter of the next).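

In this assay the lowering seen one carbon earlier does not carry on: methyl in place of hydrogen on a saturated chain carbon, two bonds along the chain from a carbonyl carbon, gives a 3.7-fold higher number from compound 3 to compound 4 (0.57 log units; beyond the scatter), so the response at this chain end changes direction. The propyl chain of compound 4 still keeps part of the earlier gain, with a 2.1-fold lower number from compound 2 to compound 4 (0.32 log units; beyond the scatter), which leaves the ethyl chain of compound 3 with the lowest number among the three chain lengths shown. The data shown offer nothing that explains this turn.

The compounds shown leave open how a longer chain such as butyl, or a branched chain such as isopropyl, would read in this assay. They also leave open whether an amine or a carboxylic acid at the chain end would keep or lose the number of compound 3.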